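A few compounds are considered here, and "the series" means these few. Any claim that something is new, unique, unknown or untested is made for them only; others in the source may bear on it.

Measured so far in a functional assay on the whole organism for inhibition, with Rattus norvegicus as the target, at a dose of 10 mg/kg by the oral route; a lower number here means a weaker effect, a higher number a stronger effect of the compound at the dose given:
compound 1 `COc1cc(C(=O)Nc2nn[nH]n2)nc(-c2ccccc2)c1`: 100%
compound 2 `COc1cc(C(=O)Nc2nn[nH]n2)nc(-c2ccc(Cl)cc2)c1`: 55%

Among the measured compounds shown here, compound 2 stands lowest of the two numbers; the nearest is compound 1, and the single step measured is a number 45 percentage points lower from compound 1 to compound 2 (beyond the scatter) (chloro in place of hydrogen on an aromatic carbon). Compound 3 `CCCCc1ccc(-c2cc(OC)cc(C(=O)Nc3nn[nH]n3)n2)cc1` differs from compound 2 as follows: butyl in place of chloro on an aromatic carbon. For the measured compounds named here, no measured step exchanges one substituent for another at this carbon, so the hydrogen-to-chloro step bears on it only loosely. For compound 3 the expected step is a number 10 percentage points lower from compound 2 to compound 3 (within the scatter), not clearly beyond the scatter, with wide uncertainty. Compound 3 is thus estimated at 45%, ranging from 10% to 85%.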

Compound 3, a percentage reported as inhibition, in the whole organism at one dose (the size of the read-out at that dose, not a potency): 92%
Compound 3: middle estimate off by 47 percentage points, on the low side, and the stated range ends below it.
By their numbers in this assay, from the lowest: compound 2; then compounds 3 and 1 (each within the scatter of the next).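

At this aromatic carbon the step with butyl in place of chloro is a number 37 percentage points higher from compound 2 to compound 3 (beyond the scatter) in this assay, so the loss seen with chloro does not extend to every substituent here. The step with butyl in place of hydrogen is a number 8 percentage points lower from compound 1 to compound 3 (within the scatter) and shows that a four-carbon chain can sit at this carbon with the effect at this dose retained. Going by these compounds, whether a methoxy group, an amine or a longer chain at this carbon would behave like butyl or like chloro stays open. Nothing available explains why chloro and butyl part here.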